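From acetyl to dimethylcarbamoyl in a mouse assay

The compounds below may be only part of what the source reports. "The series", "measured", "known", "first", "only" and "open" are said of these compounds alone.

Measured in a functional assay on the whole organism with Mus musculus as the target; on this read-out lower numbers stand for an effect already at smaller amounts and higher numbers for an effect only at larger amounts of compound:
Compound 1 `O=C(c1ccc(F)cc1)C(O)CCN1CCN(c2ccccc2)CC1`: 35 mg/kg
Compound 2 `CC(=O)OC(CCN1CCN(c2ccccc2)CC1)C(=O)c1ccc(F)cc1`: 56 mg/kg

For the measured compounds named here, compound 2 has compound 1 as its only measured neighbour, and the two values lie within the scatter of each other. Compound 3 `CN(C)C(=O)OC(CCN1CCN(c2ccccc2)CC1)C(=O)c1ccc(F)cc1` carries dimethylamino in place of methyl on a carbonyl carbon, which turns acetoxy into (dimethylcarbamoyl)oxy. Going by the values given here, the only measured step at this oxygen is a 1.6-fold higher number from compound 1 to compound 2 (0.20 log units; within the scatter). Among the compounds with values here, no measured step covers the dimethylcarbamoyl group, so no shift beyond the scatter is expected in this assay. The expected step is a 1.1-fold lower number from compound 2 to compound 3 (0.05 log units; within the scatter). The estimate for compound 3 is 50 mg/kg, with a range of 20 mg/kg to 120 mg/kg.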

Compound 3, dose for half-maximal effect: 30 mg/kg
The estimate for compound 3 lay 1.7-fold (0.22 log units) above the measured number, within the range that was stated.
By their numbers in this assay, from the lowest: compounds 3, 1 and 2 (each within the scatter of the next).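

In this assay methyl to dimethylamino on a carbonyl carbon gives a 1.9-fold lower number from compound 2 to compound 3 (0.27 log units; within the scatter) and dimethylcarbamoyl in place of hydrogen on the oxygen gives a 1.2-fold lower number from compound 1 to compound 3 (0.07 log units; within the scatter) so this oxygen has now carried hydrogen, acetyl and dimethylcarbamoyl with all three compounds within the scatter of one another. No measurement is available that bears on the reason for these numbers.

Going by these compounds, whether benzoyl or a methyl ether on this oxygen would move the number beyond the scatter stays open.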